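Replacing a Methylphenyl Group on the Shared Core

The compounds below may be only part of what the source reports. "The series", "measured", "known", "first", "only" and "open" are said of these compounds alone.

Of the compounds shown here, three sharing one core have been tested in a functional assay on U-87MG ATCC cells (Homo sapiens) for cytotoxicity, read by MTT assay, with a stated time of 72 h; on this read-out lower numbers stand for stronger inhibition and higher numbers for weaker inhibition. Compound 1 `COc1cc2c(Oc3ccc(NC(=O)c4nnn(-c5ccccc5C(F)(F)F)c4C(F)(F)F)cc3F)ccnc2cc1OCCCN1CCCC1` gives 1180 nM. Compound 2 `COc1cc2c(Oc3ccc(NC(=O)c4nnn(-c5ccc(F)cc5)c4C(F)(F)F)cc3F)ccnc2cc1OCCCN1CCC(C)CC1` gives 800 nM, and compound 3 `COc1cc2c(Oc3ccc(NC(=O)c4nnn(-c5ccc(C)cc5)c4C(F)(F)F)cc3F)ccnc2cc1OCCCN1CCC(C)CC1` gives 2800 nM. Compound 3 thus stands with the highest number of the three, meaning the weakest effect on these cells: its nearest neighbour is compound 1 and the furthest is compound 2. For the measured compounds named here, the only single-point step among the measured compounds is a 3.5-fold higher number from compound 2 to compound 3 (0.54 log units; beyond the scatter), which concerns the same position that changes next.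

Compound 4 `COc1cc2c(Oc3ccc(NC(=O)c4nnn(-c5ccccc5C(F)(F)F)c4C(F)(F)F)cc3F)ccnc2cc1OCCCN1CCC(C)CC1` is the next compound, and it differs from compound 3 in one place: 2-(trifluoromethyl)phenyl in place of 4-methylphenyl on an aromatic nitrogen. The step from compound 2 to compound 3 bears on this change, since it alters the same group on the same aromatic nitrogen, and it was modest in size. Compound 1 carries the same entering group, but it differs from compound 4 elsewhere, so its value only hints at the range. Taken together, the number for compound 4 is expected to move back down by a 2.8-fold lower number from compound 3 to compound 4 (0.45 log units; beyond the scatter) in this assay. The estimate for compound 4 is 1000 nM, with a likely range from 400 nM to 2500 nM.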

Compound 4, half-maximal inhibitory concentration: 1240 nM
Beside the measured number, compound 4's estimate is 1.2-fold (0.09 log units) below it; measured number inside the range.
By their numbers in this assay, from the lowest: compounds 2, 1 and 4 (each within the scatter of the next); then compound 3.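

In this assay, the 4-methylphenyl group of compound 3 is not the only group at this aromatic nitrogen to give a weak result in a way that could be shrugged off: a 2.3-fold lower number from compound 3 to compound 4 (0.35 log units; beyond the scatter) shows that a larger group, 2-(trifluoromethyl)phenyl, can stand here with a lower number, so added size alone does not raise it among these compounds. The 2-(trifluoromethyl)phenyl and 4-fluorophenyl groups cannot be told apart, with a 1.6-fold higher number from compound 2 to compound 4 (0.19 log units; within the scatter), and the amine at the end of the chain makes no readable difference in this pair either, with a 1.1-fold higher number from compound 1 to compound 4 (0.02 log units; within the scatter). Nothing available explains why compound 3 stands apart from compound 2 and compound 4.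

The step from compound 3 to compound 4 changes both the substituent and its place on the phenyl ring, so 2-methylphenyl and 4-(trifluoromethyl)phenyl groups would be needed to separate those two changes. An unsubstituted phenyl group would show what the substituents add at all, and a morpholin-4-yl group at the chain end would test whether the amine stays as silent beyond this single pair.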